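Compound 2 to compound 3: a group swap at the carbonyl

The source may report more compounds than this note shows. Statements on the series, on what has been measured and on what is new or still open speak of the compounds shown alone.

Measured so far in an ADME assay on HepG2 cells (Homo sapiens) for cytotoxicity; on this read-out lower numbers stand for an effect already at smaller amounts and higher numbers for an effect only at larger amounts of compound:
Compound 1 `Cc1ccc(S(=O)(=O)N[C@@H](CC(=O)NC(C)(C)C)C(=O)NCCNC(=O)c2ccccc2Cl)cc1` gives > 11000 nM as a limit
Compound 2 `COc1cc(OC)cc(C(=O)NCCNC(=O)[C@H](CC(=O)NC(C)(C)C)NS(=O)(=O)c2ccc(C)cc2)c1` gives > 11000 nM as a limit

Compound 2 stands at > 11000 nM as a limit of this assay and not a number. Among the measured compounds shown here, the series so far offers only the limit of > 11000 nM in this assay, at which 2 of the 2 values shown sit, as its evidence, so no measured value places compound 2 more exactly.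

Compound 3 `Cc1ccc(S(=O)(=O)N[C@@H](CC(=O)NC(C)(C)C)C(=O)NCCNC(=O)c2cccc(F)c2)cc1` carries 3-fluorophenyl in place of 3,5-dimethoxyphenyl on a carbonyl carbon. For the measured compounds named here, the one measured step at this place is a step that the two limits leave unreadable from compound 1 to compound 2 with 3,5-dimethoxyphenyl in place of 2-chlorophenyl, and it gives no size to carry over. From that step alone, no change beyond the scatter is expected in this assay for this swap, and compound 3 is expected to report only a limit as well. The expected change is a step that the limit leaves unreadable from compound 2 to compound 3 and no more. For compound 3 the estimated value is 15000 nM with an expected range from 7000 nM to 32000 nM on this read-out.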

Compound 3, half-maximal effective concentration: > 11000 nM
Compound 3: no number, only a limit; the forecaster's own chance of this, stated with the estimate: 85%; the middle value is on the limit's open side.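

In this assay, among the compounds shown here, compound 3 gives > 11000 nM, a limit and not a number, so no step from compound 1 or compound 2 to compound 3 can be read. The compounds shown leave open whether any of these swaps on the carbonyl carbon changes the read-out, and what number each of the three compounds would give: the limit of > 11000 nM in this assay, at which 3 of the 3 values shown sit.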